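Swapping the benzyl group for a bromophenyl one

This account rests on a few compounds, and the source may have more. Where it says the series, first, only, none or still open, it means among the compounds named here.

Measured so far:
compound 1, `COc1ccc(CN(C(=O)CSc2nc3ccccc3s2)c2cc(OC)c(OC)c(OC)c2)cc1C`: 17100 nM
compound 2, `COc1ccc(CN(C(=O)CSc2nc3ccccc3s2)c2cc(OC)c(OC)c(OC)c2)cc1Br`: 4550 nM
compound 3, `COc1ccc(CN(C(=O)CSc2nc3ccccc3s2)c2cc(OC)c(OC)c(OC)c2)cc1C(F)(F)F`: > 80000 nM

In a functional assay on HCT-116 cells (Homo sapiens) for antiproliferative activity, read by MTT assay, with a stated time of 48 h (a higher number here means a weaker inhibitor, a lower number a stronger inhibitor), compound 1 gives 17100 nM, the highest of the two numbers obtained. For compound 3 this assay reports only a limit, > 80000 nM (the limit of > 80000 nM in this assay, at which 1 of the 3 values shown sits). Compound 4, `COc1cc(N(Cc2ccc(Br)cc2)C(=O)CSc2nc3ccccc3s2)cc(OC)c1OC`, is not yet measured; it differs from compound 1 by 4-bromophenyl in place of 4-methoxy-3-methylphenyl on a saturated chain carbon bound to an amide-type nitrogen.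

Among the measured compounds shown here, no measured step makes exactly this change. The closest is a 3.8-fold lower number from compound 1 to compound 2 (0.57 log units; beyond the scatter), where bromine entering the aromatic ring lowered the number. The steps of an at least 4.6-fold higher number from compound 1 to compound 3 (0.67 log units; beyond the scatter) and an at least 17-fold higher number from compound 2 to compound 3 (1.24 log units; beyond the scatter) concern trifluoromethyl and give no direct guide. Since compound 4 likewise carries bromine on its ring while losing the methoxy and methyl groups, a modest lowering is expected, of about a 2.1-fold lower number from compound 1 to compound 4 (0.33 log units; beyond the scatter). Compound 4 is therefore estimated at 8000 nM, with a range from 2500 nM to 30000 nM.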

Compound 4, half-maximal inhibitory concentration: 63800 nM
Compound 4: middle estimate off by 8.0-fold (0.90 log units), on the low side; measured number outside the range, above it.
By their numbers in this assay, from the lowest: compound 2; then compound 1; then compound 4. At a limit, above all of these: compound 3.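

In this assay, 4-bromophenyl in place of 4-methoxy-3-methylphenyl on a saturated chain carbon bound to an amide-type nitrogen gives a 3.7-fold higher number from compound 1 to compound 4 (0.57 log units; beyond the scatter). Set against 3-bromo-4-methoxyphenyl, the same 4-bromophenyl gives a 14-fold higher number from compound 2 to compound 4 (1.15 log units; beyond the scatter), so in these compounds a bromine on this ring does not by itself bring the low number of compound 2. Compound 3 stands only at a limit: the limit of > 80000 nM in this assay, at which 1 of the 4 values shown sits. Starting from that limit, 4-bromophenyl gives an at least 1.2-fold lower number from compound 3 to compound 4 (0.09 log units; that floor lies within the scatter), so this comparison sets no order.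

As far as these compounds go, whether the gap between compound 2 and compound 4 follows the methoxy group or the place of the bromine on the ring stays open, as the two change together. Also open, from the compounds shown here alone, is how an amine or a carboxylic acid on this ring would fare.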